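Cyano in place of nitro: notes on the series

The source may hold more compounds than are shown below. What is called first, only, known or untested is meant among the compounds shown, and "the series" means these compounds.

Measured so far:
- compound 1 `C=CCc1ccc(OCc2cn(-c3cccc([N+](=O)[O-])c3)nn2)c(O)c1` gives 68.9% in growth inhibition
- compound 2 `C=CCc1cc(O)c(O)c(CN2CCC(C)CC2)c1` gives 84.2% in growth inhibition

In a functional assay on SK-N-SH cells (Homo sapiens) for inhibition, read by MTT assay, with a stated time of 72 h, tested at 50 uM (on this read-out lower numbers stand for less inhibition of growth and higher numbers for more inhibition of growth at the one concentration tested), compound 1 stands lowest of the two measured compounds. Its gap to compound 2 lies beyond the usual scatter, but the two structures differ in more than one place, so that gap says nothing about a single change.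

Not yet measured is compound 3 `C=CCc1ccc(OCc2cn(-c3cccc(C#N)c3)nn2)c(O)c1`, which keeps the core of compound 1 and carries cyano in place of nitro on an aromatic carbon, meta to a large group. The counted difference is cyano in place of nitro on an aromatic carbon and nothing else changes.

Among the measured compounds shown here, no measured pair shows this exchange, so the data give no direct size for it. The starting point is compound 1 at 68.9% in this assay, and with a single small group exchanged, no step beyond the scatter is expected in either direction. The expected a number 1.9 percentage points lower from compound 1 to compound 3 (within the scatter) is therefore small. For compound 3 the estimated value is 67% (expected range 52% to 82%).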

Compound 3, percent growth inhibition at one concentration: 78.8%
Compound 3: the middle estimate sits 11.8 percentage points below what was measured; low and high end bracket the measured number.
By their numbers in this assay, from the lowest: compounds 1, 3 and 2 (each within the scatter of the next, the first and the last beyond it).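

In this assay, the series now has a direct size for a single exchange, cyano in place of nitro on an aromatic carbon, meta to a large group: a number 9.9 percentage points higher from compound 1 to compound 3 (within the scatter). The earlier compounds shown here could not show this, as compound 1 and compound 2 differ in more than one place. At this position, and at the one concentration tested, the read-out does not separate cyano from nitro, so the two groups can be treated as interchangeable here for this pair only, and no data at hand offer an explanation for the step.

From the compounds shown here alone, whether this position accepts groups of another kind stays open: an amine, a carboxylic acid or a methoxy group at the same aromatic carbon could still give a step beyond the scatter in either direction. Also open, going by these compounds, is whether cyano in place of nitro gives a similar step on another aromatic carbon or on a different core, and a single pair cannot answer either question.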